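Exchanging the naphthalen-2-yl group of compound 1

This account rests on a few compounds, and the source may have more. Where it says the series, first, only, none or still open, it means among the compounds named here.

In an ADME assay (liver) for metabolic stability, with Liver microsome (Rattus norvegicus) as the target, using microsomes (a lower number here means slower removal, a higher number faster removal of the compound), compound 1 (`Cn1cc(-c2ccncc2)c(-c2ccc(OCc3ccc4ccccc4c3)cc2)n1`) gives 83.3 mL/min/kg and stands highest of the two measured compounds, with compound 2 (`CN(C(=O)c1cc(-c2ccccn2)[nH]n1)c1ccc(OCc2ccc3ccccc3c2)cc1`) at 30 mL/min/kg and lower by more than the scatter. For the measured compounds named here, no measured pair differs in one place only, so no single change has been isolated yet.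

Compound 3 (`Cn1cc(-c2ccncc2)c(-c2ccc(OCB3C=Cc4ccccc4N3)cc2)n1`) keeps the core of compound 1 and alters one group, on a saturated chain carbon bound to an oxygen on an aromatic ring (a group of 10 heavy atoms (8 carbon, 1 boron, 1 nitrogen; one six-membered non-aromatic ring with 2 hetero atoms, one six-membered aromatic ring of carbon only) in place of a group of 10 heavy atoms (10 carbon; 2 six-membered aromatic rings of carbon only), on a saturated chain carbon bound to an oxygen on an aromatic ring). Going by the values given here, no measurement yet shows what this exchange does. The anchor for the expectation is compound 1 at 83.3 mL/min/kg alone. The step expected a 1.2-fold lower number from compound 1 to compound 3 (0.08 log units; within the scatter) stays within the scatter of this assay and carries no firm direction. Compound 3 is estimated at 70 mL/min/kg with an expected range of 30 mL/min/kg to 130 mL/min/kg for now.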

Compound 3, clearance: 41.7 mL/min/kg
The estimate for compound 3 lay 1.7-fold (0.22 log units) above the measured number; the measured number falls inside the stated range.
By their numbers in this assay, from the lowest: compounds 2, 3 and 1 (each within the scatter of the next, the first and the last beyond it).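

In this assay, the series now has its first step confined to one place: on a saturated chain carbon bound to an oxygen on an aromatic ring, the exchange of naphthalen-2-yl for the group holding boron and nitrogen gives a 2.0-fold lower number from compound 1 to compound 3 (0.30 log units; within the scatter). This position therefore takes a group of equal heavy-atom count, with one non-aromatic ring, one hydrogen-bond donor and one hydrogen-bond acceptor, without a step that clears the scatter. No measurement on hand bears on what lies behind this result.

Still open, as far as these compounds go, is whether a quinolinyl group, with nitrogen and no boron, or a plain phenyl group in this place would stand apart from compound 1. From the compounds shown here alone, the same exchange on the core of compound 2 also remains unknown.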